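Swapping the Piperidine Nitrogen Substituent of a Ghrelin Receptor Ligand

The source may report more compounds than this note shows. Statements on the series, on what has been measured and on what is new or still open speak of the compounds shown alone.

Measured so far:
- compound 1 `COc1cccc(-n2cc3nc(-c4cccnc4C)n(C[C@H]4CCCN(Cc5ccco5)C4)c(=O)c3n2)c1`: 2.7 nM
- compound 2 `Cc1ncccc1-c1nc2cn(-c3ccccc3)nc2c(=O)n1C[C@H]1CCCN(C[C@H]2CCCO2)C1`: 190 nM
- compound 3 `COc1ccc(-n2cc3nc(-c4ccccc4C)n(CC4CCCN(C(C)C)C4)c(=O)c3n2)cc1`: 7.3 nM

In an assay on HEK293 cells for displacement of a labelled ligand from growth hormone secretagogue receptor type 1 (Homo sapiens), with a stated time of 60 min (on this read-out lower numbers stand for stronger inhibition and higher numbers for weaker inhibition), compound 1 gives the lowest number of the three; compound 3 sits beyond the usual scatter above it, and compound 2 lies far higher still. Compound 4 `COC[C@H](C)N1CCC[C@H](Cn2c(-c3cccnc3C)nc3cn(-c4cccc(OC)c4)nc3c2=O)C1` has not yet been measured. It differs from compound 1 in one place: 1-(methoxymethyl)ethyl in place of (furan-2-yl)methyl on an amine nitrogen in a ring. For the measured compounds named here, no pair of measured compounds isolates this change. Compound 3, which carries a small branched alkyl on the same kind of ring nitrogen but also differs elsewhere, still gives 7.3 nM, so a small alkyl in this position is compatible with a low number. A modest weakening is expected in this assay, and compound 4 is estimated at 5 nM (range 1.5 nM to 16 nM), a step of a 1.9-fold higher number from compound 1 to compound 4 (0.27 log units; within the scatter) that is expected to stay near the scatter.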

Compound 4, half-maximal inhibitory concentration: 1.7 nM
The estimate for compound 4 lay 2.9-fold (0.47 log units) above the measured number; measured number inside the range.
By their numbers in this assay, from the lowest: compounds 4 and 1 (each within the scatter of the next); then compound 3; then compound 2.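

In this assay, putting 1-(methoxymethyl)ethyl in place of (furan-2-yl)methyl on the amine nitrogen in the ring gives a 1.6-fold lower number from compound 1 to compound 4 (0.20 log units; within the scatter), so this pair cannot be told apart. On the core of compound 1, then, a group with no ring serves here as well as one with a five-membered aromatic ring. On these data alone, both groups contain oxygen, so it remains open how a cyclohexyl group, or a longer chain ending in an amine or a carboxylic acid, would fare on this nitrogen. No measurement here explains why the two groups give such similar numbers.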